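Moving the double bond along a pentenyl chain

A few compounds are considered here, and "the series" means these few. Any claim that something is new, unique, unknown or untested is made for them only; others in the source may bear on it.

Three compounds have numbers in a functional assay on a cell-free system (plasma) for inhibition of thromboxane A2 receptor (Homo sapiens); on this read-out lower numbers stand for stronger inhibition and higher numbers for weaker inhibition:

compound 1 `O=C(O)CCC/C=C\CC1C2CCC(O2)C1CSCCc1ccccc1`: 5500 nM
compound 2 `CCCCC(O)CSCC1C2CCC(O2)C1C/C=C\CCCC(=O)O`: 19000 nM; 10000 nM (2 entries)
compound 3 `CCC/C=C\CSCC1C2CCC(O2)C1C/C=C\CCCC(=O)O`: 5700 nM

Compound 3 has the higher of the two single numbers, yet the step of a 1.0-fold higher number from compound 1 to compound 3 (0.02 log units; within the scatter) lies within the scatter, so no order between compound 1 and compound 3 can be claimed. Among the compounds with values here, compound 2 brings only several entries, (the several entries of compound 2 in this assay, 19000 nM; 10000 nM (2 entries)), and no single step to it is given. Compound 4 `CC/C=C/CCSCC1C2CCC(O2)C1C/C=C\CCCC(=O)O` differs from compound 3 by pent-2-en-1-yl in place of pent-1-en-1-yl on a saturated chain carbon bound to a sulfur. Within the data shown here, the only measured step at that position is the one from compound 1 to compound 3, which stayed within the scatter, and the change here is smaller still, a shift of the double bond inside the same chain. Compound 4 is therefore expected to show a 1.1-fold higher number from compound 3 to compound 4 (0.02 log units; within the scatter), nothing beyond the scatter. The estimated value of compound 4 in this assay is 6000 nM, within 2500 nM to 15000 nM.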

Compound 4, half-maximal inhibitory concentration: 700 nM
For compound 4 the middle estimate is 8.6-fold (0.93 log units) above the measured one; measured number below the stated range.
By their numbers in this assay, from the lowest: compound 4; then compounds 1 and 3 (each within the scatter of the next).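

In this assay, the place of the double bond within the five-carbon chain proves to matter: pent-2-en-1-yl in place of pent-1-en-1-yl gives an 8.1-fold lower number from compound 3 to compound 4 (0.91 log units; beyond the scatter), although the two groups count the same atoms. But-1-en-1-yl in place of phenyl on a saturated chain carbon, two bonds along the chain from a sulfur, likewise gives a 7.9-fold lower number from compound 1 to compound 4 (0.90 log units; beyond the scatter), whereas the earlier exchange of benzyl for pent-1-en-1-yl stayed within the scatter. Nothing given here accounts for this difference. The compounds shown leave open whether a saturated pentyl group or a longer chain with its double bond at the same place would give a similar number.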